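Swapping a Dimethoxyphenyl for an Aminophenyl

This account rests on a few compounds, and the source may have more. Where it says the series, first, only, none or still open, it means among the compounds named here.

Compound 1, `COc1ccc(-c2nc3cccc(-c4cc(OC)c(OC)c(OC)c4)c3o2)cc1OC`, was tested in a functional assay on MCF7 cells (Homo sapiens) for antiproliferative activity, read by MTT assay, with a stated time of 48 h; a higher number here means a weaker inhibitor, a lower number a stronger inhibitor. Compound 1 gives > 25000 nM, which is a limit of this assay rather than a number. Two close relatives are known. Compound 2, `COc1cc(-c2cccc3nc(-c4ccc(Br)cc4)oc23)cc(OC)c1OC`, carries a 4-bromophenyl in place of the 3,4-dimethoxyphenyl on an aromatic carbon; in this assay compound 2 gives > 25000 nM, again a limit. Compound 3, `COc1cc(-c2nc3cccc(-c4cc(OC)c(OC)c(OC)c4)c3o2)ccc1O`, has hydrogen in place of methyl on an oxygen on an aromatic ring; in this assay compound 3 gives > 25000 nM, also a limit. The steps a step that the two limits leave unreadable from compound 1 to compound 2 and a step that the two limits leave unreadable from compound 1 to compound 3 therefore cannot be sized, and the same holds for a step that the two limits leave unreadable from compound 2 to compound 3. Compound 4, `COc1cc(-c2cccc3nc(-c4ccc(N)cc4)oc23)cc(OC)c1OC`, differs from compound 1 in one place: 4-aminophenyl in place of 3,4-dimethoxyphenyl on an aromatic carbon. Among the compounds with values here, none of the measured steps bears on this change in a readable way, so no direction can be taken from them. Given (the limit of > 25000 nM in this assay, at which 3 of the 3 values shown sit), compound 4 is expected to remain at that limit as well, with an estimated 30000 nM in the range 8000 nM to 100000 nM. This amounts to an expected step that the limit leaves unreadable from compound 1 to compound 4, which is not expected to exceed the scatter.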

Compound 4, half-maximal inhibitory concentration: > 25000 nM
Compound 4: a limit, no number (the forecaster's own chance of this, stated with the estimate: 75%); the middle value lies beyond the limit too.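

Compound 4, like compound 1, compound 2 and compound 3, sits at a limit in this assay and gives no number, so none of the steps among these four compounds can be read. On these data alone, how strongly each of them acts, and whether the groups swapped on the shared core change that at all, stays open.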